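Hydroxy in place of hydrogen on the side chain

The compounds below may be only part of what the source reports. "The series", "measured", "known", "first", "only" and "open" are said of these compounds alone.

Compound 2 `CCCCC1=C(Br)/C(=C/Br)OC1=O` holds the highest of the two numbers given in a functional assay on ZR-75-1 cells (Homo sapiens) for cytotoxicity; a lower number here means that less compound is needed, a higher number that more compound is needed for the effect: compound 2 gives 10.2 ug/mL. Its nearest neighbour is compound 3 `CCCCC1=C(Br)C(=C(Br)Br)OC1=O`, which in this assay gives 8.6 ug/mL, within the scatter of compound 2. Compound 1 `CCC[C@@H](OC(C)=O)C1=C(Br)C(=C(Br)Br)OC1=O` in this assay gives only a limit, < 0.1 ug/mL. That is the limit of < 0.1 ug/mL in this assay, at which 1 of the 3 values shown sits. Among the measured compounds shown here, the one measured step at this place is an at least 86-fold higher number from compound 1 to compound 3 (1.93 log units; beyond the scatter). Compound 4 `CCC[C@@H](O)C1=C(Br)/C(=C/Br)OC1=O` is not yet measured in this assay. Compound 4 differs from compound 2 by hydroxy in place of hydrogen on a saturated chain carbon bound to a double-bonded ring carbon and a saturated chain carbon. The expectation for compound 4 rests on an at least 86-fold higher number from compound 1 to compound 3 (1.93 log units; beyond the scatter), which concerns the same place but with acetoxy rather than hydroxy, so its size serves only as a guide. A lower number is expected for compound 4, with a large step, though the size is uncertain for hydroxy. The estimate for compound 4 in this assay is 1 ug/mL, expected to fall between 0.1 ug/mL and 8 ug/mL. This corresponds to an expected step of a 10-fold lower number from compound 2 to compound 4 (1.01 log units; beyond the scatter).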

Compound 4, concentration for half-maximal effect: < 0.1 ug/mL
Compound 4: no number, only a limit (the forecaster's own chance of this, stated with the estimate: 20%); at least 10-fold (1.00 log units) between middle value and limit.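

In this assay, free hydroxy on a saturated chain carbon bound to a double-bonded ring carbon and a saturated chain carbon now has a step of its own: an at least 100-fold lower number from compound 2 to compound 4 (2.00 log units; beyond the scatter). Until now, this place was covered only by acetoxy, with an at least 86-fold higher number from compound 1 to compound 3 (1.93 log units; beyond the scatter), so the large difference is now seen on two cores and with an oxygen substituent that carries no acetyl part. Both steps end at a limit, so neither size is a number, and the true difference between the hydrogen and oxygen compounds remains unresolved: the limit of < 0.1 ug/mL in this assay, at which 2 of the 4 values shown sit.

Open, on these data alone, is whether an oxygen is needed on this carbon at all; an amine or a methoxy group here would test that. Also open, as far as these compounds go, are the opposite configuration at this carbon and a longer chain beyond it.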